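Swapping the phenyl substituent on a weakly cytotoxic core

The compounds below may be only part of what the source reports. "The series", "measured", "known", "first", "only" and "open" are said of these compounds alone.

The first compound, compound 1 `Fc1cccc(-c2nc(Nc3ccccc3)c3cc(F)ccc3n2)c1`, is a weak inhibitor in a functional assay on U-937 cells (Homo sapiens) for cytotoxicity, read by MTT assay, with a stated time of 48 h (a lower number here means a stronger inhibitor, a higher number a weaker inhibitor), where compound 1 gives 45500 nM. Compound 2 `Oc1cccc(Nc2nc(-c3cccc(F)c3)nc3ccc(F)cc23)c1` differs from it by a hydroxy in place of hydrogen on an aromatic carbon, and in this assay compound 2 reaches only the limit of the measurement, > 50000 nM. That step, an at least 1.0-fold higher number from compound 1 to compound 2 (0.04 log units; that floor lies within the scatter), therefore says no more than that compound 2 stands at or beyond the weak end of the two values shown; the limit is recorded at the limit of > 50000 nM in this assay, at which 1 of the 2 values shown sits.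

Compound 3 `Nc1ccccc1Nc1nc(-c2cccc(F)c2)nc2ccc(F)cc12` carries a different change: 2-aminophenyl in place of 3-hydroxyphenyl on a nitrogen on an aromatic ring. For the measured compounds named here, only the step from compound 1 to compound 2 bears on the series, and it stayed within the scatter, so the expected step in this assay is a number no higher from compound 2 to compound 3 (the limit leaves the size open), a change of no more than the scatter in either direction. Compound 3 is therefore estimated at 50000 nM, with a range from 15000 nM to 150000 nM, and the assay may again report only a limit.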

Compound 3, half-maximal inhibitory concentration: 47300 nM
The estimate for compound 3 lay 1.1-fold (0.02 log units) above the measured number; the measured number falls inside the stated range.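

Set on a nitrogen on an aromatic ring, 2-aminophenyl in place of 3-hydroxyphenyl gives an at least 1.0-fold lower number from compound 2 to compound 3 (0.02 log units; that floor lies within the scatter), and this step can be read only as a floor because compound 2 stands at a limit: the limit of > 50000 nM in this assay, at which 1 of the 3 values shown sits.

The comparison with the plain phenyl ring of compound 1 is the more informative one, since both numbers are measured: amino in place of hydrogen on an aromatic carbon gives a 1.0-fold higher number from compound 1 to compound 3 (0.02 log units; within the scatter), so this change leaves the number within the scatter. Across the compounds shown, therefore, neither hydroxy nor amino on this ring gives a step beyond the scatter toward a stronger inhibitor, although the hydroxy step is itself known only as a floor.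

The compounds shown leave open whether any group on this ring can move the number beyond the scatter, and a carboxylic acid, a methoxy group or a dimethylamino group on the same ring would bear on that. They also leave open whether the amino group would give the same reading at another place on the ring, or whether a longer chain carrying an amine, in place of the ring on that nitrogen, would change the result.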